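The compounds below may be only part of what the source reports. "The series", "measured", "known", "first", "only" and "open" are said of these compounds alone.

Compound 3 `Cc1cc(NC(=O)Nc2cccc(Cl)c2)c2ccccc2n1` is one of three related ureas measured for how much compound is needed to harm cells. In an ADME assay on BJ cells (Homo sapiens) for cytotoxicity, with a stated time of 72 h (a higher number here means that more compound is needed for the effect, a lower number that less compound is needed), compound 3 gives > 25000 nM, which is a limit of the assay rather than a number. Compound 1 `Cc1cc(NC(=O)Nc2ccc(C)c(Cl)c2)c2ccccc2n1` likewise gives a limit in this assay, namely > 25000 nM. Compound 2 `COc1ccc(NC(=O)Nc2cc(C)nc3ccccc23)cc1F` gives 26000 nM in this assay. Among the measured compounds shown here, the only single-point step among them, a step that the two limits leave unreadable from compound 1 to compound 3, cannot be sized (the limit of > 25000 nM in this assay, at which 2 of the 3 values shown sit). Compound 4 `COc1ccc(NC(=O)Nc2cc(C)nc3ccccc23)cc1Cl` is not yet measured. It differs from compound 3 by methoxy in place of hydrogen on an aromatic carbon. For the measured compounds named here, no measured step covers this change; compound 2, which also carries a methoxy, gives 26000 nM. Compound 4 is therefore expected to show a step of about a number no higher from compound 3 to compound 4 (the limit leaves the size open) from compound 3, within the scatter. The estimate for compound 4 in this assay is 25000 nM, with a range from 12000 nM to 60000 nM.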

Compound 4, half-maximal effective concentration: 23000 nM
For compound 4 the middle estimate is 1.1-fold (0.04 log units) above the measured one; low and high end bracket the measured number.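

In this assay, methoxy in place of hydrogen, ortho to a chloro group and para to a large group, gives an at least 1.0-fold lower number from compound 3 to compound 4 (0.03 log units; that floor lies within the scatter), so this change now has a readable floor, although one that shows no change beyond the scatter. Methoxy in place of methyl gives an at least 1.0-fold lower number from compound 1 to compound 4 (0.03 log units; that floor lies within the scatter), which is again only a floor. With the methoxy kept, chloro in place of fluoro gives a 1.1-fold lower number from compound 2 to compound 4 (0.05 log units; within the scatter), so these two groups cannot be told apart in this assay.

Going by these compounds, the true size of the two methoxy steps stays open because they start from compounds whose values are limits and not numbers: the limit of > 25000 nM in this assay, at which 2 of the 4 values shown sit. Whether an amine or a carboxylic acid at this place would move the number beyond the scatter also remains open.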